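The source may report more compounds than this note shows. Statements on the series, on what has been measured and on what is new or still open speak of the compounds shown alone.

Values in a functional assay on NCI-H460 cells (Homo sapiens) for cytotoxicity, read by MTT assay, with a stated time of 72 h (a lower number here means a stronger inhibitor, a higher number a weaker inhibitor), for the series so far:
- compound 1 `CCCCNC1=CC(=O)C(C[C@]2(C)[C@@H](C)CC[C@]3(C)C(C)=CCC[C@@H]23)=CC1=O` gives > 100000 nM (a limit of the assay, not a number)
- compound 2 `CC1=CCC[C@H]2[C@](C)(CC3=CC(=O)C=CC3=O)[C@@H](C)CC[C@]12C` gives 24000 nM
- compound 3 `CC(C)(C)C1=CC(=O)C=C(NCc2ccccc2)C1=O` gives 10000 nM

Compound 3 at 10000 nM holds the lowest of the two actual numbers, and compound 2 at 24000 nM lies higher, beyond the scatter. Compound 1 stands at a limit, > 100000 nM, and not at a number.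

Compound 4 `CCNC1=CC(=O)C=C(C(C)(C)C)C1=O` has not yet been measured. Its difference from compound 3 is methyl in place of phenyl on a saturated chain carbon bound to an amine nitrogen.

Among the measured compounds shown here, no measured step makes this exact change. The only one that bears on it is an at least 4.1-fold lower number from compound 1 to compound 2 (0.61 log units; beyond the scatter), with hydrogen in place of butylamino on a double-bonded ring carbon. That step starts from a limit and sits on a different core, so it is weak guidance on size. Still, compound 1 in that step has a plain chain on the amine nitrogen, as compound 4 has, and it lies on the higher side of an at least 4.1-fold lower number from compound 1 to compound 2 (0.61 log units; beyond the scatter). A modest move to a higher number in this assay is therefore expected. The expected change is a 2.2-fold higher number from compound 3 to compound 4 (0.34 log units; beyond the scatter), with a limit reading not excluded. The estimate for compound 4 is 22000 nM, with an expected range of 7000 nM to 70000 nM.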

Compound 4, half-maximal inhibitory concentration: 14000 nM
Beside the measured number, compound 4's estimate is 1.6-fold (0.20 log units) above it, and the stated range covers the measured number.
By their numbers in this assay, from the lowest: compounds 3, 4 and 2 (each within the scatter of the next, the first and the last beyond it). At a limit, above all of these: compound 1.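

In this assay, the change of methyl in place of phenyl on a saturated chain carbon bound to an amine nitrogen gives a 1.4-fold higher number from compound 3 to compound 4 (0.15 log units; within the scatter), so at this place on the shared core the two groups are not told apart. A six-membered aromatic ring of carbon only is therefore not required here for a reading that is a number and not a limit, and a single carbon at this place serves as well within the scatter. The earlier step, with hydrogen in place of butylamino on a double-bonded ring carbon, concerned a different core and a whole amino group, and it could not show this; nothing measured here gives a cause for the new step.

Going by these compounds, whether a longer chain, a carboxylic acid or an amine at this place would separate from methyl and phenyl remains open. Also open, on these data alone, is whether the same equivalence would hold on the core of compound 1, where the chain on the amine nitrogen is butyl.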